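This account rests on a few compounds, and the source may have more. Where it says the series, first, only, none or still open, it means among the compounds named here.

In a functional assay on K562 cells (Homo sapiens) for cytotoxicity (a lower number here means a stronger inhibitor, a higher number a weaker inhibitor), compound 1 `C/C=C(/C)C(=O)O[C@H]1C[C@@H](O)C2=CC(=O)C(C(C)(C)OO)=C[C@]2(C)[C@H]1C` gives 46300 nM. Compound 2 `C/C=C(/C)C(=O)O[C@H]1C[C@@H](O)C2=CC(=O)C(=C(C)C)C[C@]2(C)[C@H]1C` gives only a limit in this assay, namely > 100000 nM. That reading sits at the limit of > 100000 nM in this assay, at which 1 of the 2 values shown sits, so compound 2 stands at the weak end of what is shown. Compound 3 `C/C=C(/C)C(=O)O[C@H]1C[C@@H](OC(=O)/C(C)=C/C)C2=CC(=O)C(=C(C)C)C[C@]2(C)[C@H]1C` differs from compound 2 by (1-methylprop-1-en-1-yl)carbonyl in place of hydrogen on an oxygen on a saturated carbon. Going by the values given here, no step between two measured compounds exists here, so the expectation rests on compound 2 alone. Compound 3 is expected to show a step of a number no higher from compound 2 to compound 3 (the limit leaves the size open) that stays within the scatter, in no clear direction. Compound 3 is estimated at 100000 nM, within 30000 nM to 300000 nM.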

Compound 3, half-maximal inhibitory concentration: 51100 nM
Compound 3: the middle estimate sits 2.0-fold (0.29 log units) above what was measured; measured number inside the range.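

Replacing hydrogen with (1-methylprop-1-en-1-yl)carbonyl on this oxygen still leaves a measurable reading in this assay, and the change gives an at least 1.9-fold lower number from compound 2 to compound 3 (0.29 log units; that floor lies within the scatter). This shows that the oxygen on a saturated carbon can carry this larger ester group without the reading reaching the limit. The full size of the step stays unknown because compound 2 has only a limit: the limit of > 100000 nM in this assay, at which 1 of the 3 values shown sits.

From the compounds shown here alone, whether a smaller acetyl group or a methyl group on this oxygen would give a similar reading remains open. So does whether a longer chain there would do so.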